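Trimming the benzyl ring of a sulfonylurea orexin-2 ligand

A few compounds are considered here, and "the series" means these few. Any claim that something is new, unique, unknown or untested is made for them only; others in the source may bear on it.

Of the compounds shown here, three sharing one core have been measured in an assay on HEK293 cells for displacement of a labelled ligand from Orexin receptor type 2 (Homo sapiens), read by scintillation counting, with a stated time of 90 min; a lower number here means a stronger inhibitor, a higher number a weaker inhibitor. Compound 1 `COc1ccc(N2C(=O)N(Cc3c(F)cc(F)cc3F)c3ccccc3S2(=O)=O)cc1OC` gives 2 nM, compound 2 `COc1ccc(N2C(=O)N(Cc3ccc(F)cc3Cl)c3ccccc3S2(=O)=O)cc1OC` gives 25.1 nM, and compound 3 `COc1cc(F)c(CN2C(=O)N(c3ccc(OC)c(OC)c3)S(=O)(=O)c3ccccc32)c(Cl)c1` gives 0.1 nM. Compound 3 is the most potent of the three: its number is lower than that of compound 1 by a 20-fold lower number from compound 1 to compound 3 (1.30 log units; beyond the scatter) and lower than that of compound 2 by a 250-fold lower number from compound 2 to compound 3 (2.40 log units; beyond the scatter). The next compound, compound 4 `COc1ccc(N2C(=O)N(Cc3ccccc3F)c3ccccc3S2(=O)=O)cc1OC`, is reached from compound 3 by the change (2-fluorophenyl in place of 2-chloro-6-fluoro-4-methoxyphenyl on a saturated chain carbon bound to an amide-type nitrogen in a ring). Both measured steps that end at compound 3 bear on this: replacing 2,4,6-trifluorophenyl or 2-chloro-4-fluorophenyl with 2-chloro-6-fluoro-4-methoxyphenyl gave large drops in the number, and compound 2, whose 2-chloro-4-fluorophenyl is closest to 2-fluorophenyl among the measured groups, stands at 25.1 nM. Compound 4 is therefore expected to lose a great deal, by about a 300-fold higher number from compound 3 to compound 4 (2.48 log units; beyond the scatter), in this assay . The estimate for compound 4 is 30 nM, expected to lie between 8 nM and 150 nM.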

Compound 4, inhibition constant: 6.31 nM
Compound 4: the middle estimate sits 4.8-fold (0.68 log units) above what was measured; the measured number lies below the stated range.
By their numbers in this assay, from the lowest: compound 3; then compound 1; then compound 4; then compound 2.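

The 2-fluorophenyl group shows that adding halogens to this ring does not push the number in one direction: a 4.0-fold lower number from compound 2 to compound 4 (0.60 log units; beyond the scatter), yet a 3.2-fold higher number from compound 1 to compound 4 (0.50 log units; beyond the scatter). So compound 2, with more halogen than compound 4, goes against any rule that more halogen helps, while compound 1 fits such a rule. The much larger step, a 63-fold higher number from compound 3 to compound 4 (1.80 log units; beyond the scatter), shows that the strength of compound 3 belongs to its particular 2-chloro-6-fluoro-4-methoxyphenyl group rather than to halogen on the ring alone, and no measurement here explains why these groups differ.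

On these data alone, what the methoxy contributes apart from the chlorine and fluorine of compound 3 stays open. Also open, as far as these compounds go, is how a ring carrying an amine or a carboxylic acid in place of that methoxy would behave.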